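Replacing the Cyano Group of Compound 2

The compounds below may be only part of what the source reports. "The series", "measured", "known", "first", "only" and "open" are said of these compounds alone.

Among the measured compounds shown here, compound 2 `Cc1nc(S(C)(=O)=O)ccc1Oc1ncnc(OC2CCN(C(=O)OC(C)(C)C#N)CC2)c1F` carries the highest of the two numbers measured so far; in a functional assay on isolated protein for inhibition of Glucose-dependent insulinotropic receptor (Rattus norvegicus), read by HTRF and cAMP accumulation (on this read-out higher numbers stand for an effect only at larger amounts of compound and lower numbers for an effect already at smaller amounts), compound 2 gives 1320 nM. Its nearest neighbour is compound 1 `Cc1nc(S(C)(=O)=O)ccc1Oc1ncnc(OC2CCN(C(=O)OC(C)C)CC2)c1F`, which in this assay gives 142 nM. For the measured compounds named here, the single step between them went with a cyano in place of hydrogen on a saturated chain carbon bound to an oxygen next to a carbonyl group and two saturated chain carbons. Compound 3 `Cc1nc(S(C)(=O)=O)ccc1Oc1ncnc(OC2CCN(C(=O)OC(C)(C)CF)CC2)c1F` has not yet been measured and differs from compound 2 by fluoromethyl in place of cyano on a saturated chain carbon bound to an oxygen next to a carbonyl group and two saturated chain carbons. Going by the values given here, the only step that bears on this change is a 9.3-fold higher number from compound 1 to compound 2 (0.97 log units; beyond the scatter), in which the cyano entered; as the cyano now leaves, a move back toward compound 1 is expected, although the fluoromethyl has no measured precedent here. For compound 3 an expected step of a 4.4-fold lower number from compound 2 to compound 3 (0.64 log units; beyond the scatter) is estimated, giving an expected value of 300 nM with a range from 100 nM to 900 nM.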

Compound 3, half-maximal effective concentration: 138 nM
The estimate for compound 3 lay 2.2-fold (0.34 log units) above the measured number; the range from low to high includes it.
By their numbers in this assay, from the lowest: compounds 3 and 1 (each within the scatter of the next); then compound 2.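

In this assay the result separates the cyano from the mere presence of a further group on a saturated chain carbon bound to an oxygen next to a carbonyl group and two saturated chain carbons: fluoromethyl in place of cyano goes with a 9.6-fold lower number from compound 2 to compound 3 (0.98 log units; beyond the scatter) on this carbon. Fluoromethyl in place of hydrogen on the same carbon gives a 1.0-fold lower number from compound 1 to compound 3 (0.01 log units; within the scatter) and so leaves the number where compound 1 stands, which means that among these three compounds only the cyano goes with a higher number. Nothing given here says why the two groups differ at this carbon.

Going by these compounds, whether a hydroxymethyl, a difluoromethyl or an amine on this carbon would follow the fluoromethyl or the cyano remains open. On these data alone, the compounds also share one core, so whether these steps carry over to another core remains open too.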